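The compounds below may be only part of what the source reports. "The series", "measured", "known", "first", "only" and "open" are said of these compounds alone.

Compound 1, `COc1ccc(-c2cn(CCCN3C(=O)COc4ccccc43)nn2)cc1`, gives 4900 nM in a functional assay on HeLa cells (Homo sapiens) for antiproliferative activity, read by sulforhodamine B assay, with a stated time of 48 h; on this read-out higher numbers stand for weaker inhibition of growth and lower numbers for stronger inhibition of growth. Compound 2, `CCCCCCc1cn(CCCN2C(=O)COc3ccccc32)nn1`, gives 100 nM. Compound 3, `CCCc1cn(CCCN2C(=O)COc3ccccc32)nn1`, gives 23200 nM.

Among these three numbers compound 1 stands second highest, so only compound 3 inhibits growth more weakly. Compound 4, `O=C1COc2ccccc2N1CCCn1cc(C2(O)CCCCC2)nn1`, has not yet been measured; it differs from compound 1 in one place: 1-hydroxycyclohexyl in place of 4-methoxyphenyl on an aromatic carbon. Among the measured compounds shown here, two measured steps bear on this swap of the ring group. Going from compound 1 to compound 2 the number fell, a 49-fold lower number from compound 1 to compound 2 (1.69 log units; beyond the scatter), while going from compound 1 to compound 3 it rose, a 4.7-fold higher number from compound 1 to compound 3 (0.68 log units; beyond the scatter). These point in opposite directions, so no clear direction is expected for compound 4. Compound 4 is therefore estimated near compound 1, at 4000 nM within 700 nM to 25000 nM, a step of a 1.2-fold lower number from compound 1 to compound 4 (0.09 log units; within the scatter) expected with wide uncertainty.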

Compound 4, concentration for 50% growth inhibition: 2000 nM
For compound 4 the middle estimate is 2.0-fold (0.30 log units) above the measured one, and the stated range covers the measured number.
By their numbers in this assay, from the lowest: compound 2; then compound 4; then compound 1; then compound 3.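

In this assay this position tolerates a non-aromatic ring carrying a hydrogen-bond donor: 1-hydroxycyclohexyl gives a 2.5-fold lower number from compound 1 to compound 4 (0.39 log units; beyond the scatter) when it replaces 4-methoxyphenyl. Against the chains, the same group gives a 12-fold lower number from compound 3 to compound 4 (1.06 log units; beyond the scatter) and a 20-fold higher number from compound 2 to compound 4 (1.30 log units; beyond the scatter) so it falls between propyl and hexyl, and hexyl in compound 2 keeps the lowest number. Nothing measured here explains these steps. The compounds shown do not separate the effect of the ring from that of its hydroxyl. Plain cyclohexyl, an amine on that ring, or a chain longer than hexyl could test this position further.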